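Nitro replacing fluoro on the shared core

This account rests on a few compounds, and the source may have more. Where it says the series, first, only, none or still open, it means among the compounds named here.

Measured so far:
compound 1 `Cc1[nH]c2ccc(F)cc2c1C1=CCNCC1` — 3100 nM
compound 2 `Cc1[nH]c2ccc(OS(=O)(=O)C(F)(F)F)cc2c1C1=CCNCC1` — 1800 nM

In an assay on isolated protein for displacement of a labelled ligand from 5-hydroxytryptamine receptor 7 (Homo sapiens) (a higher number here means a weaker inhibitor, a lower number a stronger inhibitor), compound 1 gives the highest of the two numbers; its nearest neighbour is compound 2, with a 1.7-fold lower number from compound 1 to compound 2 (0.24 log units; within the scatter). Compound 3 `Cc1[nH]c2ccc([N+](=O)[O-])cc2c1C1=CCNCC1` differs from compound 1 as follows: nitro in place of fluoro on an aromatic carbon. Among the measured compounds shown here, the only step that bears on this change is the one from compound 1 to compound 2, where a different group replaced the same fluoro and the number stayed within the scatter. A comparable outcome is expected here, so a 1.2-fold lower number from compound 1 to compound 3 (0.09 log units; within the scatter) is expected. For compound 3 the estimate is 2500 nM, with a range from 800 nM to 8000 nM.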

Compound 3, half-maximal inhibitory concentration: > 1000 nM
Compound 3 ended at the assay's limit; the forecaster's own chance of this, stated with the estimate: 5%; the middle value is on the limit's open side.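

Compound 3 gives > 1000 nM, a limit and not a number; the steps to compound 3 from compound 1 and compound 2 cannot be read. On these data alone, how nitro in place of fluoro changes the number remains open.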